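The source may hold more compounds than are shown below. What is called first, only, known or untested is meant among the compounds shown, and "the series" means these compounds.

Series notes. For the measured compounds named here, in an assay on a protein complex for inhibition of CDK8/Cyclin C (Homo sapiens), with a stated time of 1 h, tested at 10 uM (a lower number here means less inhibition, a higher number more inhibition at the concentration tested (going by the name of the read-out)), compound 3 `NC(=O)/C=C/c1ccncc1-c1ccc2ccccc2c1` gives 102%, the highest of the three numbers so far. Compound 2 `O=C(O)COc1ccncc1-c1ccc2ccccc2c1` gives 16% and compound 1 `O=C(COc1ccncc1-c1ccc2ccccc2c1)N1CCOCC1` gives 9%; the step of a number 7 percentage points higher from compound 1 to compound 2 (within the scatter) lies within the scatter, whereas the step of a number 86 percentage points higher from compound 2 to compound 3 (beyond the scatter) is the one large move in the set.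

Compound 4 `COC(=O)COc1ccncc1-c1ccc2ccccc2c1` is not yet measured. The change (methoxycarbonyl)methoxy in place of 2-carbamoylethenyl on an aromatic carbon removes the side chain that carried the large gain: the 2-carbamoylethenyl group leaves and a (methoxycarbonyl)methoxy group enters on an aromatic carbon. The measured step that bears on this is a number 86 percentage points higher from compound 2 to compound 3 (beyond the scatter), read in reverse, since compound 4 resembles compound 2 and compound 1 in this part of the structure and both of those sit low. For this assay a large drop is therefore expected, a number 90 percentage points lower from compound 3 to compound 4 (beyond the scatter), back to the level of compound 2 and compound 1. Compound 4 is estimated at 12%, with a range from 0% to 30%.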

Compound 4, a percentage reported as inhibition, at one concentration (the size of the read-out at that concentration, not a potency): 11%
Compound 4: the middle estimate sits 1 percentage points above what was measured; low and high end bracket the measured number.
By their numbers in this assay, from the lowest: compounds 1, 4 and 2 (each within the scatter of the next); then compound 3.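

With (methoxycarbonyl)methoxy on this aromatic carbon, this assay shows a number 91 percentage points lower from compound 3 to compound 4 (beyond the scatter), so the low level now holds for a third group ending in a carbonyl on the same oxygen-bearing side chain. The end of that side chain does not separate the compounds: the ester gives a number 5 percentage points lower from compound 2 to compound 4 (within the scatter) and a number 2 percentage points higher from compound 1 to compound 4 (within the scatter), which places hydroxy, methoxy and morpholin-4-yl on the carbonyl carbon together within the scatter. No measured evidence accounts for the gap between these side chains and 2-carbamoylethenyl.

Still open, going by these compounds, is whether the high number depends on the primary amide or on the ethenyl chain that carries it. A 2-carboxyethenyl group, a saturated 2-carbamoylethyl chain and a carbamoylmethoxy group would each separate those two parts.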